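Arylidene semicarbazide series: 4-fluorophenyl variant of compound 2

The source may report more compounds than this note shows. Statements on the series, on what has been measured and on what is new or still open speak of the compounds shown alone.

The series is followed in a functional assay on A549 cells (Homo sapiens) for cytotoxicity, read by MTT assay, with a stated time of 72 h; a higher number here means a weaker inhibitor, a lower number a stronger inhibitor. Compound 1 `CN(C)CCn1cnnc1-c1cc(Oc2ccc(NC(=O)N/N=C/c3cc(C(C)(C)C)cc(C(C)(C)C)c3O)cc2F)ccn1` gives 980 nM. Compound 2 `COc1ccc(/C=N/NC(=O)Nc2ccc(Oc3ccnc(-c4nncn4CCN(C)C)c3)c(F)c2)c(OC)c1` gives 2820 nM, the highest of the two numbers obtained, with compound 1 at the nearest value, beyond the scatter. Compound 3 `Cn1ncnc1-c1cc(Oc2ccc(NC(=O)N/N=C/c3ccccc3)cc2F)ccn1` gives only a limit of the assay, > 100000 nM, as noted in the limit of > 100000 nM in this assay, at which 1 of the 3 values shown sits.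

Compound 4 `CN(C)CCn1cnnc1-c1cc(Oc2ccc(NC(=O)N/N=C/c3ccc(F)cc3)cc2F)ccn1` has not yet been measured. It differs from compound 2 by 4-fluorophenyl in place of 2,4-dimethoxyphenyl on a carbon with a double bond to nitrogen. Among the measured compounds shown here, no measured pair covers this change. The expected step from compound 2 to compound 4 is a 2.8-fold higher number from compound 2 to compound 4 (0.45 log units; beyond the scatter), towards a weaker value. For compound 4 the estimate is 8000 nM, with a range from 2000 nM to 50000 nM.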

Compound 4, half-maximal inhibitory concentration: 1790 nM
Compound 4: middle estimate off by 4.5-fold (0.65 log units), on the high side, outside the stated range (below it).
By their numbers in this assay, from the lowest: compounds 1, 4 and 2 (each within the scatter of the next, the first and the last beyond it). At a limit, above all of these: compound 3.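

Among the compounds shown here, this is the first pair that differs in one place: in this assay, 4-fluorophenyl in place of 2,4-dimethoxyphenyl on a carbon with a double bond to nitrogen gives a 1.6-fold lower number from compound 2 to compound 4 (0.20 log units; within the scatter). At this position, the two hydrogen-bond acceptors of the leaving group can therefore go, and a smaller aromatic group can enter, without a shift beyond the scatter. No measured property available bears on this step. Open, from the compounds shown here alone, is how a carboxylic acid or an amine on a carbon with a double bond to nitrogen would read, in place of these aromatic groups.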